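From diethoxymethyl to cyclopentyl on the side chain

The source may hold more compounds than are shown below. What is called first, only, known or untested is meant among the compounds shown, and "the series" means these compounds.

In a functional assay on T98 cells (Homo sapiens) for antiproliferative activity, with a stated time of 5 days (on this read-out lower numbers stand for an effect already at smaller amounts and higher numbers for an effect only at larger amounts of compound), compound 1 `Nc1nc2cc(-c3nn(CC4OCCO4)c4ncnc(N)c34)ccc2o1` gives 100 nM, and compound 2 `CCOC(Cn1nc(-c2ccc3oc(N)nc3c2)c2c(N)ncnc21)OCC` gives 100 nM. Compound 2 therefore stands level with compound 1 at the digits given.

Compound 3 `Nc1nc2cc(-c3nn(CC4CCCC4)c4ncnc(N)c34)ccc2o1` keeps the shared core and changes one group: cyclopentyl in place of diethoxymethyl on a saturated chain carbon bound to an aromatic nitrogen. This places cyclopentyl in place of diethoxymethyl on a saturated chain carbon bound to an aromatic nitrogen. Cut one bond further out, the same difference reads 2,2-diethoxyethyl to cyclopentylmethyl.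

Within the data shown here, only one measured step bears on this place: no change at the digits printed from compound 1 to compound 2 (within the scatter). That step exchanges 1,3-dioxolan-2-yl for diethoxymethyl, so both of its groups contain oxygen. Among the measured compounds shown here, no measured compound has a group of carbon only here, which leaves the evidence for cyclopentyl thin. The working expectation is no shift beyond the scatter in either direction, held with a wide margin. The expected step in this assay is no change at the digits printed from compound 2 to compound 3 (within the scatter).

For compound 3 the estimated value is 100 nM, with an expected range of 30 nM to 350 nM.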

Compound 3, half-maximal effective concentration: 10 nM
The estimate for compound 3 lay 10-fold (1.00 log units) above the measured number, and the stated range ends above it.
By their numbers in this assay, from the lowest: compound 3; then compounds 1 and 2 (each within the scatter of the next).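

In this assay the place on a saturated chain carbon bound to an aromatic nitrogen now proves responsive to the group it carries: cyclopentyl in place of diethoxymethyl gives a 10-fold lower number from compound 2 to compound 3 (1.00 log units; beyond the scatter) in this series, and cyclopentyl in place of 1,3-dioxolan-2-yl gives a 10-fold lower number from compound 1 to compound 3 (1.00 log units; beyond the scatter) on the same core. The exchange between the two oxygen-bearing groups had left compound 1 and compound 2 level, so it could not show this sensitivity; the group of carbon only is the one that separates from them. A ring alone does not go with the lower number, since compound 1 carries a ring and still stands level with the ringless compound 2.

Nothing at hand says why cyclopentyl differs from the two oxygen-bearing groups. From the compounds shown here alone, whether the lower number belongs to cyclopentyl in particular or to carbon-only groups here in general stays open, and cyclohexyl, an open butyl chain or a tetrahydrofuran ring with a single oxygen would separate these readings.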